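A few compounds are considered here, and "the series" means these few. Any claim that something is new, unique, unknown or untested is made for them only; others in the source may bear on it.

Measured so far in a functional assay on A549 cells (Homo sapiens) for cytotoxicity, read by sulforhodamine B assay, with a stated time of 72 h; a higher number here means a weaker inhibitor, a lower number a stronger inhibitor:
- compound 1, `CCCC(=O)Nc1ccn([C@@H]2CO[C@H](CO)O2)c(=O)n1`: 6600 nM
- compound 2, `CCCCCCC(=O)Nc1ccn([C@@H]2CO[C@H](CO)O2)c(=O)n1`: 1040 nM
- compound 3, `O=C(Nc1ccn([C@@H]2CO[C@H](CO)O2)c(=O)n1)C1CCCC1`: 2970 nM

Compound 3 stands second highest of the three numbers. Its nearest neighbour is compound 1, a 2.2-fold lower number from compound 1 to compound 3 (0.35 log units; beyond the scatter); its furthest is compound 2, a 2.9-fold higher number from compound 2 to compound 3 (0.46 log units; beyond the scatter).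

Compound 4, `O=C(Nc1ccn([C@@H]2CO[C@H](CO)O2)c(=O)n1)C1CCCCC1`, differs from compound 3 by one change: cyclohexyl in place of cyclopentyl on a carbonyl carbon. For the measured compounds named here, the steps that bear on it all involve growing the group on the carbonyl carbon. a 6.3-fold lower number from compound 1 to compound 2 (0.80 log units; beyond the scatter) and a 2.2-fold lower number from compound 1 to compound 3 (0.35 log units; beyond the scatter) both lowered the number; a 2.9-fold higher number from compound 2 to compound 3 (0.46 log units; beyond the scatter) shows that the ring of five gave a higher number than the longer open chain. One more ring carbon is therefore expected to lower the number modestly in this assay, a 1.7-fold lower number from compound 3 to compound 4 (0.22 log units; within the scatter). Compound 4 is estimated at 1800 nM, within 800 nM to 4000 nM.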

Compound 4, half-maximal inhibitory concentration: 7370 nM
The estimate for compound 4 lay 4.1-fold (0.61 log units) below the measured number; measured number outside the range, above it.
By their numbers in this assay, from the lowest: compound 2; then compound 3; then compounds 1 and 4 (each within the scatter of the next).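

In this assay, for the compounds shown here, one more ring carbon on the carbonyl carbon gives a 2.5-fold higher number from compound 3 to compound 4 (0.39 log units; beyond the scatter) and so runs against the lowering seen in the earlier steps: adding carbon does not by itself lower the number at this position. Cyclohexyl compares poorly with the open hexyl chain, with a 7.1-fold higher number from compound 2 to compound 4 (0.85 log units; beyond the scatter), yet cannot be told apart from propyl, with a 1.1-fold higher number from compound 1 to compound 4 (0.05 log units; within the scatter) and no order between them. Nothing measured here explains this reversal. From the compounds shown here alone, how a phenyl ring or a chain longer than hexyl would read on this carbonyl carbon stays open.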